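Compound 4 against a lone measured number

This account rests on a few compounds, and the source may have more. Where it says the series, first, only, none or still open, it means among the compounds named here.

- Compound 1 `Cc1cc2ncccc2cc1C(C)n1cnc2ncc(-c3cnn(C)c3)nc21` – "not determined" (no result reported)
- Compound 2 `Nc1ccc(-c2cnc3ncn(Cc4ccc5ncccc5c4)c3n2)cc1` – 4950 nM
- Compound 3 `FC(F)(F)Oc1ccc(-c2cnc3ncn(Cc4ccc5ncccc5c4)c3n2)cc1` – > 10000 nM

Among the measured compounds shown here, in a functional assay on NCI-H1993 cells (Homo sapiens) for inhibition, read by CCK-8 assay, with a stated time of 72 h (on this read-out higher numbers stand for weaker inhibition and lower numbers for stronger inhibition), compound 2 holds the only exact number of the three (4950 nM), so there is little to rank it against. Compound 3 is reported only as a limit (> 10000 nM). Compound 4 `C1=C(c2cnc3ncn(Cc4ccc5ncccc5c4)c3n2)CCNC1` has yet to be measured. The change from compound 2 to compound 4 (a group of 6 heavy atoms (5 carbon, 1 nitrogen; one six-membered non-aromatic ring with 1 hetero atom) in place of a group of 7 heavy atoms (6 carbon, 1 nitrogen; one six-membered aromatic ring of carbon only), on an aromatic carbon) removes the 4-aminophenyl group from the shared core.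

For the measured compounds named here, the one measured step, an at least 2.0-fold higher number from compound 2 to compound 3 (0.30 log units; that floor lies within the scatter), keeps the aromatic ring of carbon only and swaps amino for trifluoromethoxy on it. It therefore sets no size for replacing the ring, and no step beyond the scatter is expected in this assay in either direction. The expected change is a 1.4-fold lower number from compound 2 to compound 4 (0.15 log units; within the scatter), a loose estimate resting on very little. Compound 4 is estimated at 3500 nM (expected range 800 nM to 12000 nM).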

Compound 4, half-maximal inhibitory concentration: 6660 nM
Compound 4: the middle estimate sits 1.9-fold (0.28 log units) below what was measured, within the range that was stated.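

In this assay, compound 4 puts a six-membered non-aromatic ring with 1 hetero atom on this aromatic carbon in place of the 4-aminophenyl group, and the outcome is a 1.3-fold higher number from compound 2 to compound 4 (0.13 log units; within the scatter). Across this pair, then, the aromatic ring of carbon only can be exchanged without a step beyond the scatter, something the earlier step could not show, as compound 3 kept that ring. Compound 3 remains a limit and not a number: the limit of > 10000 nM in this assay, at which 1 of the 4 values shown sits.

What the compounds shown leave open is whether any group on this carbon can give a step beyond the scatter towards stronger inhibition. A piperidine without the double bond, a morpholine or a pyridine would each test a different part of this exchange.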